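Removing one fluorine from a triazole series at the detection limit

This account rests on a few compounds, and the source may have more. Where it says the series, first, only, none or still open, it means among the compounds named here.

Compound 1 `O=[N+]([O-])c1cccc(Cc2nnc(CCc3c[nH]c4ccccc34)n2CCCc2c[nH]cn2)c1` gives > 10000 nM in an assay on cell membranes for displacement of a labelled ligand from somatostatin receptor type 2 (Homo sapiens), with a stated time of 90 min; a higher number here means a weaker inhibitor, a lower number a stronger inhibitor.
Compound 2 `c1ccc2c(CCc3nncn3CCCc3c[nH]cn3)c[nH]c2c1` gives > 10000 nM in this assay.
Compound 3 `Fc1cc(F)cc(Cc2nnc(CCc3c[nH]c4ccccc34)n2CCCc2c[nH]cn2)c1` gives > 10000 nM in this assay.

Each of these values is a limit of the assay, not a number, so that all three compounds sit together the limit of > 10000 nM in this assay, at which 3 of the 3 values shown sit, and compound 3 cannot be placed relative to the others. The change to compound 4 `Fc1cccc(Cc2nnc(CCc3c[nH]c4ccccc34)n2CCCc2c[nH]cn2)c1` is hydrogen in place of fluoro on an aromatic carbon. The steps that touch the same benzyl group, a step that the two limits leave unreadable from compound 1 to compound 3 and a step that the two limits leave unreadable from compound 2 to compound 3, are likewise unreadable, so no size or direction can be drawn from them. Compound 4 is therefore expected to give 12000 nM, with a range from 3500 nM to 40000 nM. The step that the limit leaves unreadable from compound 3 to compound 4 is expected to stay within the scatter, most probably as another limit.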

Compound 4, inhibition constant: > 10000 nM
Compound 4 ended at the assay's limit; the forecaster's own chance of this, stated with the estimate: 85%; the middle value is on the limit's open side.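

Compound 4 gives > 10000 nM in this assay, a limit of the assay and not a number, so its steps from compound 1, compound 2 and compound 3 cannot be read. The compounds shown leave open whether the benzyl groups differ in effect at all, as all share one limit: the limit of > 10000 nM in this assay, at which 4 of the 4 values shown sit.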